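The compounds below may be only part of what the source reports. "The series", "measured", "known", "first", "only" and "open" are said of these compounds alone.

Values in an ADME assay on MRC5 cells (Homo sapiens) for antiproliferative activity, read by fluorescence and resazurin assay, with a stated time of 68 h (on this read-out lower numbers stand for an effect already at smaller amounts and higher numbers for an effect only at larger amounts of compound), so far
compound 1 (`Cc1ccc(-c2cc(C(=O)NCCN3CCN(C)CC3)c3cc(Cl)ccc3n2)cc1`): 8000 nM
compound 2 (`Cc1ccc(-c2cc(C(=O)NCCN3CCCCC3)c3cc(Cl)ccc3n2)cc1`): 7000 nM

Among the compounds with values here, compound 2 stands level with compound 1, the only other measured compound, and the two values lie within the scatter of each other. Compound 3 (`Cc1ccc(-c2cc(C(=O)NCCN3CCCC3)c3cc(Cl)ccc3n2)cc1`) keeps the rest of compound 2 and carries pyrrolidin-1-yl in place of piperidin-1-yl on a saturated chain carbon, two bonds along the chain from an amide-type nitrogen. Within the data shown here, one measured step bears on this, with piperidin-1-yl in place of 4-methylpiperazin-1-yl at the same place (a 1.1-fold lower number from compound 1 to compound 2 (0.06 log units; within the scatter)). Going by that single small step, no change beyond the scatter is expected in this assay and no direction can be given. The expected step is small (no change at the digits printed from compound 2 to compound 3 (within the scatter)). The estimate for compound 3 is 7000 nM with an expected range (3500 nM to 14000 nM).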

Compound 3, half-maximal effective concentration: 7000 nM
For compound 3 middle estimate and measured number coincide at the digits printed, within the range that was stated.
By their numbers in this assay, from the lowest: compounds 2, 3 and 1 (each within the scatter of the next).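

In this assay, the ring size of the saturated amine at this place can now be read directly: pyrrolidin-1-yl in place of piperidin-1-yl gives no change at the digits printed from compound 2 to compound 3 (within the scatter), and pyrrolidin-1-yl in place of 4-methylpiperazin-1-yl gives a 1.1-fold lower number from compound 1 to compound 3 (0.06 log units; within the scatter). On a saturated chain carbon, two bonds along the chain from an amide-type nitrogen, all three ring amines shown therefore read alike, and the one-atom difference between the five-membered and six-membered rings leaves no mark beyond the scatter. No measurement at hand offers an explanation for this flat reading.

As far as these compounds go, whether this flatness extends to an open-chain amine such as dimethylamino, to morpholin-4-yl or to a carboxylic acid at this place remains open. Also open, from the compounds shown here alone, is the outcome with a longer chain between the amide nitrogen and the ring.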